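The source may hold more compounds than are shown below. What is called first, only, known or untested is meant among the compounds shown, and "the series" means these compounds.

Working notes on the series. Of the compounds shown here, two have numbers so far in a functional assay on MOLT-4 cells (Homo sapiens) for antiproliferative activity, read by MTT assay, with a stated time of 48 h; on this read-out higher numbers stand for weaker inhibition and lower numbers for stronger inhibition. Compound 1 `O=C(CCCCCCn1cc(Nc2ncc(Cl)c(Nc3cccc(Cl)c3)n2)cn1)NO` gives 130 nM. Compound 2 `O=C(CCCCCn1cc(Nc2ncc(Cl)c(Nc3ccccc3Cl)n2)cn1)NO` gives 630 nM, the higher of the two numbers and so the weaker inhibition, with a gap to compound 1 that lies beyond the scatter.

Next is compound 3 `O=C(CCCCCCn1cc(Nc2ncc(Cl)c(Nc3ccccc3Cl)n2)cn1)NO`, also to be read in this assay. The change from compound 2 is (hydroxycarbamoyl)methyl in place of hydroxycarbamoyl on a saturated chain carbon, five bonds along the chain from an aromatic nitrogen.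

Among the measured compounds shown here, no measured step isolates this change, so the data give no direct support for its size. The only anchor is the span of the two measured values, with compound 1 at 130 nM as its lower end. A moderate fall in the number, towards stronger inhibition, is expected, of a size that may only just clear the scatter. The expected change is a 2.1-fold lower number from compound 2 to compound 3 (0.32 log units; beyond the scatter). Compound 3 is estimated at 300 nM, with an expected range of 110 nM to 800 nM.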

Compound 3, half-maximal inhibitory concentration: 510 nM
Beside the measured number, compound 3's estimate is 1.7-fold (0.23 log units) below it; the measured number falls inside the stated range.
By their numbers in this assay, from the lowest: compound 1; then compounds 3 and 2 (each within the scatter of the next).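

In this assay, (hydroxycarbamoyl)methyl in place of hydroxycarbamoyl on a saturated chain carbon, five bonds along the chain from an aromatic nitrogen, gives a 1.2-fold lower number from compound 2 to compound 3 (0.09 log units; within the scatter), so this one-carbon extension of the chain does not separate the two compounds on this read-out. The same compound also isolates the other place: 2-chlorophenyl in place of 3-chlorophenyl on a nitrogen on an aromatic ring gives a 3.9-fold higher number from compound 1 to compound 3 (0.59 log units; beyond the scatter), which shows that, with the chain held constant, the chlorophenyl change alone moves the number beyond the scatter, something the earlier pair, differing in both places at once, could not show. Nothing on hand offers an explanation for either step.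

Compound 1 is the only compound shown with 3-chlorophenyl, so whether the chlorophenyl step holds at the chain length of compound 2 stays open. Also open, as far as these compounds go, are whether a longer chain ending in 4-(hydroxycarbamoyl)butyl would move the number beyond the scatter, and how a carboxylic acid in place of the hydroxycarbamoyl end would read.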